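Exchanging One Ring on a Chain Carbon

This account rests on a few compounds, and the source may have more. Where it says the series, first, only, none or still open, it means among the compounds named here.

In an ADME assay on the whole organism for pharmacokinetics, with Rattus norvegicus as the target (on this read-out lower numbers stand for lower oral bioavailability and higher numbers for higher oral bioavailability), compound 1 (`COc1nc2ccc(Br)cc2cc1[C@@H](c1cc(C)c(C)s1)[C@@](O)(CCN(C)C)c1cccc(F)c1`) gives 48% as its result, and compound 2 (`COc1nc2ccc(Br)cc2cc1[C@@H](c1ccnc(OC)c1OC)[C@@](O)(CCN(C)C)c1cccc(C)c1`) gives 40% as its own. These two numbers are all that has been measured so far, and they lie within the usual scatter of each other, so compound 1 cannot be told apart from compound 2 on this read-out.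

Compound 3 (`CCSc1ccc([C@H](c2cc3cc(Br)ccc3nc2OC)[C@@](O)(CCN(C)C)c2cccc(F)c2)cn1`) keeps the rest of compound 1 but carries 6-(ethylsulfanyl)pyridin-3-yl in place of 4,5-dimethylthiophen-2-yl on a saturated chain carbon bound to an aromatic carbon and a saturated chain carbon. Among the compounds with values here, no measured pair shows what this exchange does in this assay, so no step beyond the scatter is expected in either direction. The estimated step is a number 6 percentage points lower from compound 1 to compound 3 (within the scatter) and would stay within that scatter. For compound 3 the expected value is 42% (estimated range 22% to 62%).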

Compound 3, oral bioavailability: 30%
Compound 3: the middle estimate sits 12 percentage points above what was measured; the measured number falls inside the stated range.
By their numbers in this assay, from the lowest: compounds 3, 2 and 1 (each within the scatter of the next, the first and the last beyond it).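

The ring on this saturated chain carbon matters for this assay: replacing 4,5-dimethylthiophen-2-yl with 6-(ethylsulfanyl)pyridin-3-yl gives a number 18 percentage points lower from compound 1 to compound 3 (beyond the scatter) while the rest of compound 1 stays the same. Within the data shown here, this is the first change in a single place that can be read here, and it shows that this position can shift the read-out by more than repeat measurements would. No measurement shown here explains the step.

From the compounds shown here alone, the exchange changes several things at once, from a five-membered to a six-membered aromatic ring, with a ring nitrogen and an ethylsulfanyl chain entering as the two methyl groups leave, so the share of each remains unknown. Also open, going by these compounds, is how the read-out would respond if a methylsulfanyl group or an amine took the place of the ethylsulfanyl chain.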